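The compounds below may be only part of what the source reports. "The series", "measured", "known", "first", "only" and "open" are said of these compounds alone.

The series shares the core of compound 1 `COc1ccc(C(c2ccccc2O)c2cccc3ccccc23)c(OC)c1OC`. In a functional assay on HCT-116 cells (Homo sapiens) for inhibition, read by sulforhodamine B assay, with a stated time of 48 h (a lower number here means a stronger inhibitor, a higher number a weaker inhibitor), compound 1 gives only a limit, > 20000 nM, so where compound 1 stands on the numbers shown remains open-ended. Compound 2 `COc1ccc(/C(=N/OC(C)=O)c2cccc3ccccc23)c(OC)c1OC` is measured in the same assay; compound 2 gives 4980 nM. Among the compounds with values here, no single-change step between measured compounds is available, so no measured step size can be quoted. The unmeasured compound 3 `COc1ccc(C(OCc2ccccc2)c2cccc3ccccc23)c(OC)c1OC` differs from compound 1 by benzyloxy in place of 2-hydroxyphenyl on a saturated chain carbon bound to two aromatic carbons. Because compound 1 sits at the limit of > 20000 nM in this assay, at which 1 of the 2 values shown sits, the direction of this change cannot be read from the data. The expected step of an at least 1.3-fold lower number from compound 1 to compound 3 (0.12 log units; that floor lies within the scatter) is taken as modest and toward a stronger inhibitor, with a real chance that the assay again reports only a limit. Compound 3 is therefore expected to give 15000 nM in this assay, within 4000 nM to 40000 nM.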

Compound 3, half-maximal inhibitory concentration: > 20000 nM
Compound 3: no number, only a limit; the forecaster's own chance of this, stated with the estimate: 45%; middle value at least 1.3-fold (0.12 log units) from the limit.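

No step can be read between compound 1 and compound 3, because each gives only a limit: the limit of > 20000 nM in this assay, at which 2 of the 3 values shown sit.
The compounds shown leave open whether benzyloxy in place of 2-hydroxyphenyl changes inhibition at all, and how far either compound lies beyond that limit.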